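This account rests on a few compounds, and the source may have more. Where it says the series, first, only, none or still open, it means among the compounds named here.

In a functional assay on M21 cells (Homo sapiens) for antiproliferative activity, read by sulforhodamine B assay, with a stated time of 48 h (on this read-out higher numbers stand for weaker inhibition and lower numbers for stronger inhibition), three compounds with a shared core have been measured. Compound 1 (`O=C1NCCN1c1ccc(S(=O)(=O)Nc2ccc(F)cc2)cc1`) gives 230 nM, compound 2 (`CCc1cccc(NS(=O)(=O)c2ccc(N3CCNC3=O)cc2)c1`) gives 82 nM, and compound 3 (`O=C1NCCN1c1ccc(S(=O)(=O)Nc2cccc(Br)c2)cc1`) gives 59 nM. Compound 3 thus sits at the low end of these numbers together with compound 2, with a 1.4-fold lower number from compound 2 to compound 3 (0.14 log units; within the scatter), whereas the gap to the remaining compound is a 3.9-fold lower number from compound 1 to compound 3 (0.59 log units; beyond the scatter). Compound 4 (`Cc1ccc(C)c(NS(=O)(=O)c2ccc(N3CCNC3=O)cc2)c1`) is still unmeasured. It carries 2,5-dimethylphenyl in place of 3-bromophenyl on a sulfonamide nitrogen. For the measured compounds named here, no measured compound carries this group, so the evidence is indirect. The nearest guides are the other changes at that nitrogen, namely a 2.8-fold lower number from compound 1 to compound 2 (0.45 log units; beyond the scatter) and the bromo-for-ethyl step already given. These suggest that a change there can move the number modestly or not beyond the scatter. In this assay, a modest step towards a higher number is therefore expected, given as a 2.0-fold higher number from compound 3 to compound 4 (0.31 log units; beyond the scatter). For compound 4 the estimated value is 120 nM, with an expected range from 40 nM to 400 nM.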

Compound 4, half-maximal inhibitory concentration: 27 nM
Compound 4: the middle estimate sits 4.4-fold (0.65 log units) above what was measured; the whole stated range lies above it.
By their numbers in this assay, from the lowest: compound 4; then compounds 3 and 2 (each within the scatter of the next); then compound 1.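

In this assay, 2,5-dimethylphenyl on a sulfonamide nitrogen gives the lowest number of the series, with a 2.2-fold lower number from compound 3 to compound 4 (0.34 log units; beyond the scatter) and a 3.0-fold lower number from compound 2 to compound 4 (0.48 log units; beyond the scatter), so a phenyl group carrying two methyl groups outdoes both the 3-bromophenyl and the 3-ethylphenyl group at this position. For the compounds shown here, measured against the 4-fluorophenyl group, the change at this nitrogen reaches an 8.5-fold lower number from compound 1 to compound 4 (0.93 log units; beyond the scatter), which widens the span seen at this position so far. Nothing shown here accounts for these differences.

The compounds shown leave open whether a single methyl group on the phenyl ring would give a similar number, and how a phenyl ring carrying an amine or a carboxylic acid would behave at this nitrogen. They also leave open how the number responds to changes elsewhere on the shared core.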